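Methyl in place of vinyl on the aryl amide: compound 4

The source may hold more compounds than are shown below. What is called first, only, known or untested is meant among the compounds shown, and "the series" means these compounds.

Measured so far in a functional assay on HEK293 cells for agonist activity at D(4) dopamine receptor (Homo sapiens), read by FLIPR; a lower number here means that less compound is needed, a higher number that more compound is needed for the effect:
Compound 1 `Cc1cccc(NC(=O)CN2CCC(c3ccc(O)cc3)CC2)c1` gives 70 nM.
Compound 2 `C=Cc1cccc(C(=O)NCN2CCC(c3cccc[n+]3[O-])CC2)c1` gives 68 nM.
Compound 3 `COc1cc(C(=O)NCN2CCC(c3cccc[n+]3[O-])CC2)ccc1Cl` gives 159 nM.

Compound 2 shows the lowest number of the three, but compound 1 sits within the scatter of it, so no order between compound 1 and compound 2 can be read from these two values. Compound 3 stands beyond the scatter on the higher side.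

Compound 4 `Cc1cccc(C(=O)NCN2CCC(c3cccc[n+]3[O-])CC2)c1` has not been measured. It differs from compound 2 as follows: methyl in place of vinyl on an aromatic carbon. Within the data shown here, no pair of measured compounds carries this same change, so there is no measured step to lean on. Compound 1 does carry a methyl on its aryl ring, but on a different core, and its value is only a loose hint that a methyl-bearing aryl amide can give a number in the same region as compound 2.

The change is small in what leaves and what enters, so the step is expected to stay within the scatter, with no direction to call beyond it; the expected step is a 1.3-fold higher number from compound 2 to compound 4 (0.12 log units; within the scatter). For compound 4 the estimate in this assay is 90 nM, with a range from 35 nM to 250 nM.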

Compound 4, half-maximal effective concentration: 89 nM
Estimate against measurement, compound 4: 1.0-fold (0.00 log units) above; measured number inside the range.
By their numbers in this assay, from the lowest: compounds 2, 1, 4 and 3 (each within the scatter of the next, the first and the last beyond it).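

Read in this assay, the exchange of 3-vinylphenyl for 3-methylphenyl gives a 1.3-fold higher number from compound 2 to compound 4 (0.12 log units; within the scatter) as the first step in the series between compounds that differ in one place. On an aromatic carbon meta to a large group, the double bond of the vinyl group is thus not required for a number in this region, since compound 4 stays within the scatter of compound 2. Nothing measured on hand accounts for this outcome.

Going by these compounds, how much this position tolerates stays open: ethyl, an amine or a carboxylic acid on the same carbon would show whether the flat response extends beyond these two small carbon groups. On these data alone, the reading also rests on a single pair, so whether the same exchange behaves alike on the core of compound 1 is unknown.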